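Changing one aryl group in an ecdysone receptor agonist series

The compounds below may be only part of what the source reports. "The series", "measured", "known", "first", "only" and "open" are said of these compounds alone.

Of the compounds shown here, three sharing one core have been measured in an assay on cells for agonist activity at ecdysone receptor (Bombyx mori), read by a luciferase reporter, with a stated time of 24 h; a higher number here means that more compound is needed for the effect, a lower number that less compound is needed. Compound 1 `CC(C)(C)N(NC(=O)c1ccccc1F)C(=O)c1ccccc1Cl` gives 51.3 nM. Compound 2 `CC(C)(C)N(NC(=O)c1ccccc1Br)C(=O)c1ccccc1Cl` gives 316 nM in this assay, and the step of a 6.2-fold higher number from compound 1 to compound 2 (0.79 log units; beyond the scatter) came with bromo in place of fluoro. Compound 3 `COc1cccc(C(=O)NN(C(=O)c2ccccc2Cl)C(C)(C)C)c1` gives 52.5 nM, which places it second highest of the three numbers, with compound 1 within the scatter of it and compound 2 furthest away, as the step of a 6.0-fold lower number from compound 2 to compound 3 (0.78 log units; beyond the scatter) shows. The step of a 1.0-fold higher number from compound 1 to compound 3 (0.01 log units; within the scatter) shows that exchanging one aryl group for another left the number essentially unchanged.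

Compound 4 `Cc1ccc(C(=O)NN(C(=O)c2ccccc2Cl)C(C)(C)C)c(C)c1` has not yet been measured. Its difference from compound 3 is this: 2,4-dimethylphenyl in place of 3-methoxyphenyl on a carbonyl carbon. For the measured compounds named here, no measured step involves 2,4-dimethylphenyl, so the aryl swap behind a 1.0-fold higher number from compound 1 to compound 3 (0.01 log units; within the scatter) is the closest guide, while a 6.2-fold higher number from compound 1 to compound 2 (0.79 log units; beyond the scatter) warns that a change on that ring can move the number modestly. A step of about a 1.5-fold higher number from compound 3 to compound 4 (0.18 log units; within the scatter) is therefore expected, toward a somewhat higher number but plausibly still within the scatter. Compound 4 is estimated at 80 nM, with a range of 30 nM to 250 nM.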

Compound 4, half-maximal effective concentration: 162 nM
Estimate against measurement, compound 4: 2.0-fold (0.31 log units) below; the measured number falls inside the stated range.
By their numbers in this assay, from the lowest: compounds 1 and 3 (each within the scatter of the next); then compounds 4 and 2 (each within the scatter of the next).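

In this assay, the earlier swap between 2-fluorophenyl and 3-methoxyphenyl suggested that this carbonyl carbon might accept different aryl groups with no effect on the number, but 2,4-dimethylphenyl shows that this does not hold for every aryl group. Both a 3.1-fold higher number from compound 3 to compound 4 (0.49 log units; beyond the scatter) and a 3.2-fold higher number from compound 1 to compound 4 (0.50 log units; beyond the scatter) lie beyond the scatter, though each is modest. In contrast, a 2.0-fold lower number from compound 2 to compound 4 (0.29 log units; within the scatter) stays within the scatter, so among these four compounds the 2,4-dimethylphenyl and 2-bromophenyl groups form one pair and the 2-fluorophenyl and 3-methoxyphenyl groups another.

These compounds leave open how a phenyl ring carrying a single methyl group, or one carrying an amine or a carboxylic acid, would behave at this place. No evidence is at hand that explains the differences between these aryl groups.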